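This account rests on a few compounds, and the source may have more. Where it says the series, first, only, none or still open, it means among the compounds named here.

Measured compounds:
- compound 1, `COc1ccc(-c2cc(=O)c3c(OC)cc(OC)cc3n2Cc2ccccc2)cc1`: > 34400 nM (a limit of the assay)
- compound 2, `COc1ccc(-c2cc(=O)c3c(OC)cc(OC)cc3n2S(=O)(=O)c2ccc(C#N)cc2)cc1`: 7900 nM
- compound 3, `COc1ccc(-c2cc(=O)c3c(OC)cc(OC)cc3n2S(=O)(=O)c2cc(F)c(F)c(F)c2)cc1`: > 65500 nM (a limit of the assay)

All three share one core and differ only in the group on the ring nitrogen. For the measured compounds named here, in a functional assay on SUP-B15 cells (Homo sapiens) for antiproliferative activity, with a stated time of 72 h (a higher number here means that more compound is needed for the effect, a lower number that less compound is needed), compound 2 is the only one with a measured number, giving 7900 nM. For compound 3 this assay reports only a limit, > 65500 nM, so compound 3 stands at the weak end of what can be seen here (the limit of > 65500 nM in this assay, at which 1 of the 3 values shown sits). Compound 1 likewise sits at a limit, > 34400 nM (the limit of > 34400 nM in this assay, at which 1 of the 3 values shown sits).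

Compound 4, `COc1ccc(-c2cc(=O)c3c(OC)cc(OC)cc3n2S(=O)(=O)c2cccc(Br)c2)cc1`, is not yet measured. The change is 3-bromophenyl in place of 3,4,5-trifluorophenyl on a sulfonyl sulfur. Going by the values given here, the one measured step on the same sulfonyl sulfur, an at least 8.2-fold higher number from compound 2 to compound 3 (0.91 log units; beyond the scatter), shows that swapping the aryl group there can move the number beyond the scatter. A 3-bromophenyl is neither of the two aryl groups seen, so the direction is uncertain; a move back toward the number of compound 2 is possible but not assured. Compound 4 is therefore expected to give about 30000 nM, within 6000 nM to 100000 nM, which would mean a step of an at least 2.1-fold lower number from compound 3 to compound 4 (0.33 log units; beyond the scatter).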

Compound 4, half-maximal effective concentration: > 58600 nM
Compound 4: only a limit was reported (the forecaster's own chance of this, stated with the estimate: 50%); at least 1.9-fold (0.29 log units) between middle value and limit.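

In this assay, compound 4 is reported only as a limit, > 58600 nM. For the compounds shown here, putting 3-bromophenyl in place of 4-cyanophenyl on the sulfonyl sulfur gives an at least 7.4-fold higher number from compound 2 to compound 4 (0.87 log units; beyond the scatter), so 4-cyanophenyl remains the only aryl group on this sulfur with a measured number rather than a limit. The steps to compound 4 from compound 3 and from compound 1 cannot be read, with a limit at both ends of each.

Going by these compounds, it stays open whether the measured activity depends on the nitrile itself or on the whole 4-cyanophenyl group. A plain phenyl, or a phenyl carrying an amine or a carboxylic acid, on the sulfonyl sulfur also remains untested among the compounds shown, so how such groups would compare is unknown.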